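The compounds below may be only part of what the source reports. "The series", "measured", "known", "first", "only" and "open" are said of these compounds alone.

Working notes: in an ADME assay on Huh-7 cells (Homo sapiens) for cytotoxicity, read by MTT assay, with a stated time of 4 h, at 37 degrees C (on this read-out higher numbers stand for lower toxicity in this test and lower numbers for higher toxicity in this test), compound 1 (`O=C1Nc2nc(Nc3ccccc3)nc(On3nnc4ccccc43)c2CC1c1ccc(F)cc1`) gives 12200 nM and lies within the scatter of compound 3 (`O=c1[nH]c2nc(Nc3ccccc3)[nH]c(=O)c2cc1-c1ccc(F)cc1`) at 13500 nM in this small set, while compound 2 (`O=C1Nc2nc(Nc3ccccc3)nc(On3nnc4ccccc43)c2CC1c1ccc(Cl)cc1Cl`) stands lower at 5500 nM of the three. Compound 4 (`O=C1Nc2nc(Oc3ccccc3)nc(On3nnc4ccccc43)c2CC1c1ccc(F)cc1`) carries phenoxy in place of anilino on an aromatic carbon. All three measured compounds keep anilino, so the data lack a direct reading of this swap. Among the compounds with values here, the only measured step, a 2.2-fold lower number from compound 1 to compound 2 (0.35 log units; beyond the scatter) as a modest change, concerns a different group and offers only a rough guide to size. No step beyond the scatter is therefore expected in this assay in either direction. The expected step is a 1.1-fold lower number from compound 1 to compound 4 (0.04 log units; within the scatter) for now. Compound 4 is estimated at 11000 nM with a range from 5000 nM to 24000 nM as working limits.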

Compound 4, half-maximal cytotoxic concentration: 62700 nM
Estimate against measurement, compound 4: 5.7-fold (0.76 log units) below, and the stated range ends below it.
By their numbers in this assay, from the lowest: compound 2; then compounds 1 and 3 (each within the scatter of the next); then compound 4.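

In this assay this position, between two ring nitrogen atoms, proves sensitive to the group it carries: phenoxy in place of anilino gives a 5.1-fold higher number from compound 1 to compound 4 (0.71 log units; beyond the scatter) and so reads as lower toxicity in this test. Within the data shown here, this change, which leaves the rest of compound 1 untouched, has a larger effect than any seen among the earlier compounds. Nothing available explains this step.

Going by these compounds, whether phenylthio or N-methylanilino at this position would track phenoxy or anilino remains open. Also open, on these data alone, is whether the step persists with 2,4-dichlorophenyl in place of 4-fluorophenyl.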